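The source may hold more compounds than are shown below. What is called first, only, known or untested is meant among the compounds shown, and "the series" means these compounds.

Compound 3 `Fc1ccc(NC(=S)N/N=C/c2ccc(Oc3ccccc3)cc2)cc1` stands second highest of the three compounds measured in a physicochemical assay for lipophilicity, in phosphate buffer, measured as octanol-water partition, with a stated time of 24 h (a higher number here means a more lipophilic compound, a lower number a more polar compound), where compound 3 gives 5.09. Compound 1 `Cc1ccc(Oc2ccc(/C=N/NC(=S)Nc3ccc(F)cc3)cc2)cc1` gives 5.48, and compound 2 `O=[N+]([O-])c1ccc(Oc2ccc(/C=N/NC(=S)Nc3ccc(F)cc3)cc2)cc1` gives 4.89. Compound 4 `Fc1ccc(NC(=S)N/N=C/c2ccc(Oc3ccc(F)cc3)cc2)cc1` has not yet been measured; it differs from compound 3 by fluoro in place of hydrogen on an aromatic carbon. Within the data shown here, no measured step replaces hydrogen with fluoro, but two steps alter the same aromatic carbon: a number 0.39 log units lower from compound 1 to compound 3 (beyond the scatter) and a number 0.20 log units higher from compound 2 to compound 3 (within the scatter). Neither involves fluoro, so they give only a rough guide, and the expected step is small, a number 0.11 log units higher from compound 3 to compound 4 (within the scatter), probably a slight rise that stays within the scatter. Compound 4 is therefore expected to give about 5.2, with a range from 4.9 to 5.6.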

Compound 4, partition coefficient: 5.19
Beside the measured number, compound 4's estimate is 0.01 log units above it; the range from low to high includes it.
By their numbers in this assay, from the lowest: compounds 2, 3, 4 and 1 (each within the scatter of the next, the first and the last beyond it).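

In this assay, among these compounds, fluoro on this aromatic carbon, para to a large group, is the first group whose steps to all the other groups tested here lie within the scatter: in place of hydrogen (a number 0.10 log units higher from compound 3 to compound 4 (within the scatter)), in place of nitro (a number 0.30 log units higher from compound 2 to compound 4 (within the scatter)) and in place of methyl (a number 0.29 log units lower from compound 1 to compound 4 (within the scatter)). Methyl and nitro, by contrast, stand beyond the scatter of each other (a number 0.59 log units lower from compound 1 to compound 2 (beyond the scatter)). No measurement given here accounts for these steps.

From the compounds shown here alone, whether an amine, a carboxylic acid or a longer chain at this position would fall outside the span of these four values stays open. So does whether fluoro would give a similar step on a different core.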